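Swapping a cyclopentyl for an aryl group on the amine

The compounds below may be only part of what the source reports. "The series", "measured", "known", "first", "only" and "open" are said of these compounds alone.

The three measured compounds share one core and differ only in the group attached to an amine nitrogen on a double-bonded ring carbon. Compound 1 `O=C1C(NC2CCCC2)=CC(=O)c2c1nc1n2[C@H]2OC[C@@H](O)[C@H]2OC1` carries a cyclopentyl there. In a functional assay on ECa-109 cells for inhibition, with ECa-109 cell line (Homo sapiens) as the target, read by sulforhodamine B assay (on this read-out higher numbers stand for weaker inhibition and lower numbers for stronger inhibition), compound 1 gives > 16000 nM, which is a limit of the assay and not a number. Compound 2 `O=C1C=C(Nc2ccc(I)cc2)C(=O)c2c1nc1n2[C@H]2OC[C@@H](O)[C@H]2OC1` carries a (4-iodophenyl)amino group and in this assay compound 2 gives 2300 nM. Compound 3 `O=C1C=C(N2CCCCC2)C(=O)c2c1nc1n2[C@H]2OC[C@@H](O)[C@H]2OC1` carries a piperidin-1-yl group; in this assay compound 3 gives > 8000 nM, again a limit of the assay. Within the data shown here, the one measured step, an at least 3.4-fold higher number from compound 2 to compound 3 (0.54 log units; beyond the scatter), shows that replacing the aryl amine by a saturated ring amine weakens inhibition.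

Compound 4 `CCCc1ccc(NC2=CC(=O)c3c(nc4n3[C@H]3OC[C@@H](O)[C@H]3OC4)C2=O)cc1` arises from compound 1 by 4-propylphenyl in place of cyclopentyl on an amine nitrogen. This runs opposite to the measured step: a saturated ring leaves and an aryl group enters, as in compound 2. Compound 4 is therefore expected to inhibit more strongly than compound 1, with an estimated step of an at least 5.3-fold lower number from compound 1 to compound 4 (0.72 log units; beyond the scatter). For compound 4 a value of 3000 nM is estimated, within 1000 nM to 12000 nM.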

Compound 4, half-maximal inhibitory concentration: > 4000 nM
Compound 4 was reported as a limit; the forecaster's own chance of this, stated with the estimate: 20%; middle value at least 1.3-fold (0.12 log units) from the limit.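

Compound 1 and compound 4 are both reported only as limits of the assay, not as numbers, so the step between them cannot be read. The compounds shown leave open whether 4-propylphenyl in place of cyclopentyl on an amine nitrogen changes inhibition at all.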